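Benzimidazole in place of the imine arm of compound 1

The compounds below may be only part of what the source reports. "The series", "measured", "known", "first", "only" and "open" are said of these compounds alone.

Measured compounds and their values:
compound 1 `O=c1cc(/C=N\c2ccc(O)cc2)c2ccc(OCc3ccccc3)cc2o1` — 525000 nM
compound 2 `O=c1cc(/C=N\O)c2c(OCc3ccccc3)cc(OCc3ccccc3)cc2o1` — > 2000000 nM
compound 3 `N/N=C\c1cc(=O)oc2cc(OCc3ccccc3)cc(OCc3ccccc3)c12` — 36500 nM

In a functional assay, read by spectrophotometry, with a stated time of 5 min (a higher number here means a weaker inhibitor, a lower number a stronger inhibitor), compound 1 gives 525000 nM, the highest of the two numbers in hand. Compound 3 gives 36500 nM, a lower number than compound 1. For compound 2 this assay reports only a limit, and compound 2 sits at the limit of > 2000000 nM in this assay, at which 1 of the 3 values shown sits. For the measured compounds named here, the one step that can be sized, an at least 54-fold lower number from compound 2 to compound 3 (1.73 log units; beyond the scatter), concerns the group on the double-bonded nitrogen of the hydrazone arm and nothing else.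

Compound 4 `O=c1cc(-c2nc3ccccc3[nH]2)c2ccc(OCc3ccccc3)cc2o1` differs from compound 1 by a group of 9 heavy atoms (7 carbon, 2 nitrogen; one five-membered aromatic ring with 2 hetero atoms, one six-membered aromatic ring of carbon only) in place of a group of 9 heavy atoms (7 carbon, 1 nitrogen, 1 oxygen; one six-membered aromatic ring of carbon only), on an aromatic carbon. Going by the values given here, this change touches a different part of the core than the measured step, and there is no pair in the set that exchanges a whole arm of this kind for an aromatic heterocycle. The step from compound 2 to compound 3 therefore does not transfer to compound 4, and no direction can be read from the data for this exchange. The expectation is accordingly a step within the scatter, with a wide range, giving a 1.8-fold lower number from compound 1 to compound 4 (0.24 log units; within the scatter) as the estimated step. Compound 4 is expected at 300000 nM in this assay, estimated between 30000 nM and 1800000 nM.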

Compound 4, half-maximal inhibitory concentration: 146000 nM
Compound 4: middle estimate off by 2.1-fold (0.31 log units), on the high side; measured number inside the range.
By their numbers in this assay, from the lowest: compound 3; then compound 4; then compound 1. At a limit, above all of these: compound 2.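

In this assay, for the compounds shown here, replacing the whole imine arm with 1H-benzimidazol-2-yl gives a 3.6-fold lower number from compound 1 to compound 4 (0.56 log units; beyond the scatter) and is the first sized step at this aromatic carbon opposite the ring oxygen, whereas the earlier sized step changed only the group on a double-bonded nitrogen. A lower number at this position therefore does not depend on keeping the double bond outside aromatic rings or the hydroxy-bearing six-membered ring of compound 1: a fused aromatic heterocycle attached directly to the core is accepted here, and the number moves down rather than up. Going by these compounds alone, nothing measured so far accounts for the size or direction of this step.

Open, going by these compounds, is whether a benzoxazol-2-yl or a plain phenyl group at this carbon would give a similar lower number, which would show how much of the step belongs to the ring nitrogens. Also open, on these data alone, is whether the same exchange carries over to the core with two benzyloxy groups seen in compound 3, and whether an amine or a carboxylic acid on the six-membered ring of the benzimidazole would move the number further.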